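The source may hold more compounds than are shown below. What is called first, only, known or untested is meant among the compounds shown, and "the series" means these compounds.

Working notes on the series. All three measured compounds share one core. Compound 1 `O=C(CSc1nc(Nc2ccccc2)c2ccccc2n1)Nc1ccccc1Br` and compound 2 `O=C(CSc1nc(Nc2ccccc2)c2ccccc2n1)Nc1cccc(Cl)c1` differ only on the amide-type nitrogen. In a functional assay on MDA-MB-231 cells (Homo sapiens) for inhibition, read by MTT assay, with a stated time of 72 h (a higher number here means a weaker inhibitor, a lower number a stronger inhibitor), compound 1 gives 14100 nM and compound 2 gives 16500 nM; the step is a 1.2-fold higher number from compound 1 to compound 2 (0.07 log units; within the scatter). Compound 3 `C=CC(=O)Nc1cccc(NC(=O)CSc2nc(Nc3cccc(F)c3)c3ccccc3n2)c1` gives 8160 nM in this assay, the lowest of the three numbers; its gap to compound 1 lies within the scatter, its gap to compound 2 just beyond it.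

Compound 4 `C=CC(=O)Nc1cccc(NC(=O)CSc2nc(Nc3ccc(C(F)(F)F)cc3)c3ccccc3n2)c1` is not yet measured. The change from compound 3 is 4-(trifluoromethyl)phenyl in place of 3-fluorophenyl on a nitrogen on an aromatic ring. For the measured compounds named here, no measured pair varies the ring on the nitrogen on the aromatic ring; the only measured step, a 1.2-fold higher number from compound 1 to compound 2 (0.07 log units; within the scatter), concerns the amide-type nitrogen and was within the scatter, so it bears only loosely on this change. The expected step is a 1.0-fold higher number from compound 3 to compound 4 (0.02 log units; within the scatter), with nothing beyond the scatter anticipated. Compound 4 is estimated at 8500 nM, with a range from 3000 nM to 25000 nM.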

Compound 4, half-maximal inhibitory concentration: 11500 nM
The estimate for compound 4 lay 1.4-fold (0.13 log units) below the measured number; measured number inside the range.
By their numbers in this assay, from the lowest: compounds 3, 4, 1 and 2 (each within the scatter of the next, the first and the last beyond it).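

Swapping 3-fluorophenyl for 4-(trifluoromethyl)phenyl on a nitrogen on an aromatic ring gives, in this assay, a 1.4-fold higher number from compound 3 to compound 4 (0.15 log units; within the scatter), and this is the only measured pair that varies this ring. The entering group has 10 heavy atoms against 7 for the group it replaces, yet compound 3 and compound 4 cannot be told apart in this assay, so this position accepts this larger aryl group without a shift beyond the scatter. Nothing at hand bears on the reason for this result.

The pair changes the substituent and its place on the ring together, so the contribution of each remains unresolved. It also leaves open whether the position would accept a ring carrying an amine or a carboxylic acid, or a plain alkyl chain in place of the aryl ring.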